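Swapping the amide aryl group: chlorine in place of ethyl

The compounds below may be only part of what the source reports. "The series", "measured", "known", "first", "only" and "open" are said of these compounds alone.

Measured so far in a functional assay on MDA-MB-231 cells (Homo sapiens) for inhibition, read by MTT assay, with a stated time of 72 h; on this read-out lower numbers stand for stronger inhibition and higher numbers for weaker inhibition:
compound 1 `O=C(CSc1nc(Nc2ccccc2)c2ccccc2n1)Nc1ccccc1Cl` — 24400 nM
compound 2 `O=C(CSc1nc(Nc2ccccc2)c2ccccc2n1)Nc1cccc(F)c1` — > 50000 nM
compound 3 `CCc1cccc(NC(=O)CSc2nc(Nc3ccccc3)c3ccccc3n2)c1` — 12400 nM

All three share one core and differ only in the ring on the amide nitrogen. In this assay compound 1 gives 24400 nM. Compound 2 reaches only the limit of the assay, > 50000 nM. Compound 3 gives 12400 nM, and on the numbers shown it sits alongside compound 1, since the gap a 2.0-fold lower number from compound 1 to compound 3 (0.29 log units; within the scatter) is within the scatter.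

Compound 4 `O=C(CSc1nc(Nc2ccccc2)c2ccccc2n1)Nc1ccc(Cl)cc1` is not yet measured. It differs from compound 3 by 4-chlorophenyl in place of 3-ethylphenyl on an amide-type nitrogen. Going by the values given here, the steps that bear on this are an at least 2.0-fold higher number from compound 1 to compound 2 (0.31 log units; beyond the scatter) and an at least 4.0-fold lower number from compound 2 to compound 3 (0.60 log units; beyond the scatter), both beyond the scatter, with one of the values sitting at the limit of > 50000 nM in this assay, at which 1 of the 3 values shown sits. Rings carrying chlorine or fluorine gave the higher numbers, the ethyl ring the lower one. Compound 4, which carries chlorine, is therefore expected to show a modestly higher number, a 2.4-fold higher number from compound 3 to compound 4 (0.38 log units; beyond the scatter), with a real chance that only a limit is reported. The estimate for compound 4 is 30000 nM, ranging from 12000 nM to 80000 nM.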

Compound 4, half-maximal inhibitory concentration: 17200 nM
Beside the measured number, compound 4's estimate is 1.7-fold (0.24 log units) above it, within the range that was stated.
By their numbers in this assay, from the lowest: compounds 3, 4 and 1 (each within the scatter of the next). At a limit, above all of these: compound 2.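

Chlorine on the ring does not by itself raise the number in this assay: a 1.4-fold higher number from compound 3 to compound 4 (0.14 log units; within the scatter), so the 4-chlorophenyl ring sits level with the 3-ethylphenyl ring. Changing the 2-chlorophenyl ring to the 4-chlorophenyl ring also makes no readable difference, with a 1.4-fold lower number from compound 1 to compound 4 (0.15 log units; within the scatter), while the one clear separation, an at least 2.9-fold lower number from compound 2 to compound 4 (0.46 log units; beyond the scatter), sets the 3-fluorophenyl ring apart from the others. That separation rests on a limit rather than a true number: the limit of > 50000 nM in this assay, at which 1 of the 4 values shown sits.

Still open, going by these compounds, is whether the standing of the 3-fluorophenyl ring goes with fluorine itself, which a chlorine in its place on that ring would help to settle. Also open, on these data alone, is how the amide ring would read if it carried an amine or a carboxylic acid.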